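Butyl to allyl on the chain carbon by the amide-type nitrogen

The compounds below may be only part of what the source reports. "The series", "measured", "known", "first", "only" and "open" are said of these compounds alone.

Two compounds of the series have been run in a functional assay on L1210 cells (Mus musculus) for inhibition; on this read-out lower numbers stand for stronger inhibition and higher numbers for weaker inhibition. Compound 1 `CCCCNC(=O)OC/C=C(\C)C1=CC(=O)C(C)(C)O1` gives 2.6 ug/mL and stands lowest of the two numbers. Compound 2 `C/C(=C\C=C\c1ccccc1)C1=CC(=O)C(C)(C)O1` gives 14 ug/mL; its number lies well above that of compound 1, beyond the scatter. Among the measured compounds shown here, no step between measured compounds that differ in one place has been recorded, so the size of the next step rests on the structural change alone.

Compound 3 `C=CCNC(=O)OC/C=C(\C)C1=CC(=O)C(C)(C)O1` differs from compound 1 in one place: vinyl in place of propyl on a saturated chain carbon bound to an amide-type nitrogen. The rest of the structure is kept. For the measured compounds named here, with no measured step of this kind to lean on, the expectation is a change no larger than the scatter, in either direction, so the step of a 1.2-fold higher number from compound 1 to compound 3 (0.06 log units; within the scatter) is estimated as small. Compound 3 is accordingly expected to give about 3 ug/mL in this assay, within a range from 1.2 ug/mL to 7.5 ug/mL.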

Compound 3, half-maximal inhibitory concentration: 6.2 ug/mL
Estimate against measurement, compound 3: 2.1-fold (0.32 log units) below; the range from low to high includes it.
By their numbers in this assay, from the lowest: compound 1; then compound 3; then compound 2.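

Among the compounds shown here, the chain on the amide-type nitrogen is not a silent position in this assay, a point the earlier compounds could not show, since they differ in more than one place. Vinyl in place of propyl on a saturated chain carbon bound to an amide-type nitrogen gives a 2.4-fold higher number from compound 1 to compound 3 (0.38 log units; beyond the scatter), so within this pair the butyl chain holds the lower number. Butyl to allyl alters chain length and brings in a double bond in the same step, and no measurement on hand says why the number moves.

Going by these compounds, whether a saturated propyl chain on that nitrogen would fall with compound 1 or with compound 3 remains open, and so separates length from the double bond. On these data alone, a longer chain such as hexyl, or a benzyl group, at the same place is also open.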